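This account rests on a few compounds, and the source may have more. Where it says the series, first, only, none or still open, it means among the compounds named here.

Measured compounds in a functional assay on HeLa cells (Homo sapiens) for cytotoxicity, read by MTT assay; on this read-out higher numbers stand for weaker inhibition and lower numbers for stronger inhibition:
- compound 1, `CC(C)=CC[C@@H](OC(=O)c1ccoc1)C1=CC(=O)c2c(O)ccc(O)c2C1=O`: compound 1 gives > 100000 nM, a limit of the assay rather than a number.
- compound 2, `CC(=O)OCCO[C@H](CC=C(C)C)C1=CC(=O)c2c(O)ccc(O)c2C1=O`: compound 2 gives 41500 nM.
- compound 3, `CC(C)=CC[C@@H](OC(=O)c1ccco1)C1=CC(=O)c2c(O)ccc(O)c2C1=O`: compound 3 gives 80300 nM.

Compound 3 stands with compound 2 on the two numbers shown: the step of a 1.9-fold higher number from compound 2 to compound 3 (0.29 log units; within the scatter) lies within the scatter, so the two are not told apart. Compound 1 sits at the limit (the limit of > 100000 nM in this assay, at which 1 of the 3 values shown sits), and only that is known of it.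

Compound 4, `COCCO[C@H](CC=C(C)C)C1=CC(=O)c2c(O)ccc(O)c2C1=O`, differs from compound 3 in one place: 2-methoxyethyl in place of (furan-2-yl)carbonyl on an oxygen on a saturated carbon. Within the data shown here, two measured steps bear on this exchange. The step of an at least 2.4-fold lower number from compound 1 to compound 2 (0.38 log units; beyond the scatter), at least modest, replaced a (furan-3-yl)carbonyl on the same oxygen with 2-acetoxyethyl; the step of a 1.9-fold higher number from compound 2 to compound 3 (0.29 log units; within the scatter), within the scatter, went the other way, from 2-acetoxyethyl to (furan-2-yl)carbonyl. The present change again trades the (furan-2-yl)carbonyl for an acyclic group, here 2-methoxyethyl, so a small move toward a lower number, at most at the edge of the scatter, is what the series supports. The step of a 1.6-fold lower number from compound 3 to compound 4 (0.21 log units; within the scatter) is accordingly expected to be small and in the direction of a lower number. Compound 4 is estimated at 50000 nM, with a range from 20000 nM to 110000 nM.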

Compound 4, half-maximal inhibitory concentration: 62400 nM
Estimate against measurement, compound 4: 1.2-fold (0.10 log units) below, within the range that was stated.
By their numbers in this assay, from the lowest: compounds 2, 4 and 3 (each within the scatter of the next). At a limit, above all of these: compound 1.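

In this assay, the step of a 1.3-fold lower number from compound 3 to compound 4 (0.11 log units; within the scatter) puts the ring-free 2-methoxyethyl in place of the (furan-2-yl)carbonyl, with its five-membered aromatic ring, on an oxygen on a saturated carbon, and it lies within the scatter. The step of a 1.5-fold higher number from compound 2 to compound 4 (0.18 log units; within the scatter) adds a closer comparison, methyl in place of acetyl, and it too leaves the two compounds not told apart, so compound 2, compound 3 and compound 4 form one group of values on this read-out, with no pair among these steps separated. The step of an at least 1.6-fold lower number from compound 1 to compound 4 (0.20 log units; that floor lies within the scatter) gives only a floor, and that floor lies within the scatter. Compound 1 stands at a limit of the assay and not a number: the limit of > 100000 nM in this assay, at which 1 of the 4 values shown sits.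

Whether any group on this oxygen can move the value beyond the scatter stays open, since an amine or a carboxylic acid at the end of the ethyl chain, or a longer chain, does not appear among these compounds. Nor do these compounds show whether the furan-3-yl and furan-2-yl esters differ, with compound 1 at its limit.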